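Trimming the sulfonamide chain in a 11B2 series

This account rests on a few compounds, and the source may have more. Where it says the series, first, only, none or still open, it means among the compounds named here.

Three compounds share one core and differ only at the group on the amine nitrogen. Compound 1 `Cc1cccnc1C(=O)NCc1cncc(N2C(=O)c3ccc(Cl)cc3C2(C)C)c1` gives 9 nM in an assay on cells for inhibition of cytochrome P450 11B2, mitochondrial (Homo sapiens), read by HTRF; a higher number here means a weaker inhibitor, a lower number a stronger inhibitor. Compound 2 `CC(=O)NCc1cncc(N2C(=O)c3ccc(Cl)cc3C2(C)C)c1` gives 59 nM, a change of a 6.6-fold higher number from compound 1 to compound 2 (0.82 log units; beyond the scatter). Compound 3 `CCS(=O)(=O)NCc1cncc(N2C(=O)c3ccc(Cl)cc3C2(C)C)c1` gives 92 nM; this is the highest of the three numbers, but the step of a 1.6-fold higher number from compound 2 to compound 3 (0.19 log units; within the scatter) lies within the scatter, so compound 3 and compound 2 cannot be ordered, while the step of a 10-fold higher number from compound 1 to compound 3 (1.01 log units; beyond the scatter) sets compound 3 clearly apart from compound 1.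

Compound 4 `CC1(C)c2cc(Cl)ccc2C(=O)N1c1cncc(CNS(C)(=O)=O)c1`, not yet measured, differs from compound 3 by hydrogen in place of methyl on a saturated chain carbon bound to a sulfonyl sulfur. Among the measured compounds shown here, no measured step bears on this change directly. The closest guide is the swap from acetyl to ethylsulfonyl, a 1.6-fold higher number from compound 2 to compound 3 (0.19 log units; within the scatter), which stayed within the scatter even though it exchanged a carbonyl for a sulfonyl group and lengthened the chain. Removing one methyl from the chain on the sulfonyl sulfur is a smaller change still, so he expects no step beyond the scatter in this assay and no clear direction.

The step from compound 3 to compound 4 is therefore estimated as a 1.1-fold higher number from compound 3 to compound 4 (0.04 log units; within the scatter). Compound 4 is expected to give about 100 nM, in the range 45 nM to 220 nM.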

Compound 4, half-maximal inhibitory concentration: 33 nM
The estimate for compound 4 lay 3.0-fold (0.48 log units) above the measured number; the whole stated range lies above it.
By their numbers in this assay, from the lowest: compound 1; then compounds 4, 2 and 3 (each within the scatter of the next, the first and the last beyond it).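

In this assay the result shows that the chain on the sulfonyl sulfur is not a silent position: a 2.8-fold lower number from compound 3 to compound 4 (0.45 log units; beyond the scatter) lies beyond the scatter, although only one methyl gives way to hydrogen, whereas every earlier step exchanged a whole group on the amine nitrogen. The sulfonyl-for-carbonyl exchange still gives no separation, since a 1.8-fold lower number from compound 2 to compound 4 (0.25 log units; within the scatter) lies within the scatter, as the step to the ethylsulfonyl compound did, so compound 4 and compound 2 cannot be ordered, even though the methylsulfonyl and ethylsulfonyl compounds themselves do separate. The (3-methylpyridin-2-yl)carbonyl group keeps compound 1 apart, with a 3.7-fold higher number from compound 1 to compound 4 (0.56 log units; beyond the scatter) beyond the scatter, and compound 1 remains the strongest inhibitor of the four.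

Still open, on these data alone, is how a longer chain such as propyl, or a trifluoromethyl group, on the sulfonyl sulfur would read, and so whether the step seen here continues in any direction or belongs to this one pair alone. Nothing in the data shown explains why losing this methyl lowers the number.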